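Pyrrolidinyl in Place of Cyclohexylamino on the Shared Core

The source may hold more compounds than are shown below. What is called first, only, known or untested is meant among the compounds shown, and "the series" means these compounds.

Compound 3 `O=C(Nc1cc(C(F)(F)F)ccc1NC1CCCCC1)c1ccncc1` gives 59000 nM in a functional assay on NALM-6 cells (Homo sapiens) for cytotoxicity, read by MTT assay, with a stated time of 48 h; on this read-out higher numbers stand for weaker inhibition and lower numbers for stronger inhibition; compound 2 `O=C(Nc1cc(C(F)(F)F)ccc1Nc1ccc(Br)cc1)c1ccncc1` gives 51900 nM, and the two values lie within the scatter of each other, so neither can be ranked. Compound 1 `O=C(Nc1cc(C(F)(F)F)ccc1N1CCCC1)c1cccnc1Cl`, which carries a different amide portion, is reported as "not active" (no number reported). The move to compound 4 `O=C(Nc1cc(C(F)(F)F)ccc1N1CCCC1)c1ccncc1` replaces (pyrrolidin-1-yl in place of cyclohexylamino on an aromatic carbon). Among the measured compounds shown here, the only measured step at this position, a 1.1-fold higher number from compound 2 to compound 3 (0.06 log units; within the scatter), was within the scatter, and no measured step covers the change to a ring closed onto the nitrogen; the amide part of compound 1 differs, so its result transfers only loosely. Compound 4 is therefore expected to give 80000 nM, between 30000 nM and 300000 nM, an expected step of a 1.4-fold higher number from compound 3 to compound 4 (0.13 log units; within the scatter).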

Compound 4, half-maximal inhibitory concentration: "not active" (no number reported)
No number was reported for compound 4; the estimate stays without a comparison.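

In this assay compound 4 carries no number, so no step from compound 3 to compound 4 can be read, and nothing shown accounts for this result. The compounds shown leave open how pyrrolidin-1-yl compares numerically with cyclohexylamino on the shared core.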